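A Methylated Oxadiazole in Place of an Unsubstituted One

The source may report more compounds than this note shows. Statements on the series, on what has been measured and on what is new or still open speak of the compounds shown alone.

Compound 1, `CCc1c(OC)nc2nc(-c3nnco3)cn2c1C`: > 50 mg/kg
Compound 2, `CCc1c(SC)nc2nc(-c3nc(C)cs3)cn2c1C`: > 50 mg/kg
Compound 3, `CCOC(=O)c1csc(-c2cn3c(C)c(CC)c(OC)nc3n2)n1`: > 50 mg/kg

The read-out throughout is a functional assay on the whole organism with Rattus norvegicus as the target; on this read-out higher numbers stand for an effect only at larger amounts of compound and lower numbers for an effect already at smaller amounts. Compound 1 gives > 50 mg/kg in this assay, and that figure is a limit of the assay, not a measured number. Compound 2 likewise gives > 50 mg/kg, which is also a limit. Compound 3 gives > 50 mg/kg, once more a limit. Compound 1 therefore stands at the limit of > 50 mg/kg in this assay, at which 3 of the 3 values shown sit. For the measured compounds named here, since none of the three compounds yielded a number, no order among them can be read, and no measured step between any pair is available.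

The compound still to be tested is compound 4, `CCc1c(OC)nc2nc(-c3nc(C)no3)cn2c1C`. It differs from compound 1 in one place: 3-methyl-1,2,4-oxadiazol-5-yl in place of 1,3,4-oxadiazol-2-yl on an aromatic carbon. Going by the values given here, with no measured step anywhere in this set to lean on, the expectation for this change is no step beyond the usual scatter, in either direction. Compound 4 is therefore expected to give about 50 mg/kg in this assay, most plausibly between 20 mg/kg and 120 mg/kg, with a real chance that it too is reported only as a limit. The estimated step of a number no higher from compound 1 to compound 4 (the limit leaves the size open) is thus expected to be essentially flat.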

Compound 4, minimum effective dose: 5 mg/kg
Estimate against measurement, compound 4: 10-fold (1.00 log units) above; the measured number lies below the stated range.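

Swapping 1,3,4-oxadiazol-2-yl for 3-methyl-1,2,4-oxadiazol-5-yl on the shared core gives, in this assay, an at least 10-fold lower number from compound 1 to compound 4 (1.00 log units; beyond the scatter), so what sits at this place on the core can decide whether an effect appears at smaller amounts of compound. Before this result the set held no measured number, and it gave no sign that any group shown could bring the effect within the doses read; compound 4 is now the only compound with a real number, while the rest stay at a limit: the limit of > 50 mg/kg in this assay, at which 3 of the 4 values shown sit. The two groups match in ring size, in the count of hetero atoms and in the count of hydrogen-bond acceptors, so they differ in the extra methyl and in how the ring atoms are arranged.

The compounds shown leave open which of these two differences carries the step, since neither 1,2,4-oxadiazol-5-yl without its methyl nor a methylated 1,3,4-oxadiazol-2-yl appears among them. Also open, as far as these compounds go, is what happens when an ethyl group or a primary amine takes the place of that methyl.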